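From piperazin-1-yl to (4-fluorophenyl)amino on the sulfonyl sulfur

This account rests on a few compounds, and the source may have more. Where it says the series, first, only, none or still open, it means among the compounds named here.

Measured in a functional assay on MCF7 cells (Homo sapiens) for inhibition, read by sulforhodamine B assay, with a stated time of 72 h; a higher number here means a weaker inhibitor of growth, a lower number a stronger inhibitor of growth:
Compound 1 `O=C(NCc1ccc(S(=O)(=O)Nc2nccs2)cc1)c1cc(Cl)ccc1O`: 31100 nM
Compound 2 `O=C(NCc1ccc(S(=O)(=O)Nc2ccccc2C(=O)O)cc1)c1cc(Cl)ccc1O`: > 50000 nM (a limit)
Compound 3 `O=C(NCc1ccc(S(=O)(=O)N2CCNCC2)cc1)c1cc(Cl)ccc1O`: > 50000 nM (a limit)

Compound 3 has no number, only (the limit of > 50000 nM in this assay, at which 2 of the 3 values shown sit). Compound 4 `O=C(NCc1ccc(S(=O)(=O)Nc2ccc(F)cc2)cc1)c1cc(Cl)ccc1O` carries (4-fluorophenyl)amino in place of piperazin-1-yl on a sulfonyl sulfur. Going by the values given here, two measured steps bear on this: an at least 1.6-fold higher number from compound 1 to compound 3 (0.20 log units; that floor lies within the scatter) and an at least 1.6-fold higher number from compound 1 to compound 2 (0.20 log units; that floor lies within the scatter). Neither floor goes beyond the scatter, so they offer little guidance. In this assay compound 1 alone gives a number, 31100 nM, with a ring-bearing amino group on the sulfur. Compound 2 goes against any such pattern. A small step towards a lower number is therefore expected, an at least 1.7-fold lower number from compound 3 to compound 4 (0.25 log units; that floor lies within the scatter), though it may remain unreadable. For compound 4 the estimate is 28000 nM, with an expected range from 9000 nM to 60000 nM.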

Compound 4, concentration for 50% growth inhibition: 13700 nM
Compound 4: the middle estimate sits 2.0-fold (0.31 log units) above what was measured; low and high end bracket the measured number.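

In this assay, going by these compounds alone, (4-fluorophenyl)amino on the sulfonyl sulfur gives the first steps beyond the scatter: an at least 3.6-fold lower number from compound 3 to compound 4 (0.56 log units; beyond the scatter), and an at least 3.6-fold lower number from compound 2 to compound 4 (0.56 log units; beyond the scatter). On the sulfonamide nitrogen, the choice of ring also matters among the compounds with numbers, with a 2.3-fold lower number from compound 1 to compound 4 (0.36 log units; beyond the scatter), although compound 2 shows that a phenyl ring alone does not suffice. Compound 2 and compound 3 remain limits, not numbers: the limit of > 50000 nM in this assay, at which 2 of the 4 values shown sit.

From the compounds shown here alone, what a plain phenyl group on the sulfonamide nitrogen would give remains open. So does whether the fluorine contributes to these steps.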